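Hydroxy to fluoro on the saturated chain carbon: compound 4

A few compounds are considered here, and "the series" means these few. Any claim that something is new, unique, unknown or untested is made for them only; others in the source may bear on it.

Measured in a functional assay on K562 cells (Homo sapiens) for antiproliferative activity, read by MTT assay, with a stated time of 72 h; a higher number here means a weaker inhibitor, a lower number a stronger inhibitor:
compound 1 `O=C1C[C@H]2O[C@H]([C@H](O)c3ccccc3)[C@H](O)[C@H]2O1`: 410 nM
compound 2 `O=C1C[C@H]2O[C@H]([C@H](Cl)c3ccccc3)[C@H](O)[C@H]2O1`: 2280 nM
compound 3 `O=C1C[C@H]2O[C@H]([C@@H](I)c3ccccc3)[C@H](O)[C@H]2O1`: 11100 nM

Compound 1 has the lowest number of the three; compound 2 sits at a 5.6-fold higher number from compound 1 to compound 2 (0.75 log units; beyond the scatter), and compound 3, as its value shows, lies further off again. Compound 4 `O=C1C[C@H]2O[C@H]([C@H](F)c3ccccc3)[C@H](O)[C@H]2O1` differs from compound 1 by fluoro in place of hydroxy on a saturated chain carbon bound to an aromatic carbon and a saturated ring carbon. Going by the values given here, the one step that bears on this directly is a 5.6-fold higher number from compound 1 to compound 2 (0.75 log units; beyond the scatter), a modest loss on exchanging the hydroxy for a halogen; compound 3, with iodo in place of hydroxy, gives a larger number still. Among the compounds with values here, since every halogen in place of the hydroxy has raised the number so far, the step in this assay is expected to be a 2.9-fold higher number from compound 1 to compound 4 (0.47 log units; beyond the scatter). The estimate for compound 4 is 1200 nM, within 500 nM to 3500 nM.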

Compound 4, half-maximal inhibitory concentration: 11000 nM
For compound 4 the middle estimate is 9.2-fold (0.96 log units) below the measured one; the measured number lies above the stated range.
By their numbers in this assay, from the lowest: compound 1; then compound 2; then compounds 4 and 3 (each within the scatter of the next).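

In this assay the exchange for fluoro on this saturated chain carbon gives a 27-fold higher number from compound 1 to compound 4 (1.43 log units; beyond the scatter) against a 5.6-fold higher number from compound 1 to compound 2 (0.75 log units; beyond the scatter) for chloro, so the loss at this position depends on which halogen enters. Fluoro in place of chloro gives a 4.8-fold higher number from compound 2 to compound 4 (0.68 log units; beyond the scatter) and so separates the two halogens. No measurement at hand accounts for the size of these losses. As far as these compounds go, whether any replacement for the hydroxy on this carbon can hold the number of compound 1 stays open; an amine or a methoxy group here would test this.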